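Sulfonate ester anilides: amide chain variation

The source may report more compounds than this note shows. Statements on the series, on what has been measured and on what is new or still open speak of the compounds shown alone.

Measured so far:
compound 1, `CCC(=O)Nc1cccc(S(=O)(=O)Oc2ccccc2C(C)C)c1` — 14000 nM
compound 2, `CCCCCC(=O)Nc1cccc(S(=O)(=O)Oc2ccccc2C(C)C)c1` — 12000 nM

In a functional assay on MCF7 cells (Homo sapiens) for antiproliferative activity, read by sulforhodamine B assay, with a stated time of 48 h (a higher number here means a weaker inhibitor, a lower number a stronger inhibitor), compound 1 gives 14000 nM and compound 2 gives 12000 nM. Compound 2 has the lowest of the two numbers, but the step of a 1.2-fold lower number from compound 1 to compound 2 (0.07 log units; within the scatter) is within the scatter, so the two are not distinguishable on the data shown.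

Compound 3, `CC(C)c1ccccc1OS(=O)(=O)c1cccc(NC(=O)CCCl)c1`, differs from compound 2 by chloro in place of propyl on a saturated chain carbon, two bonds along the chain from a carbonyl carbon. Among the compounds with values here, the only measured step that touches this part of the molecule is a 1.2-fold lower number from compound 1 to compound 2 (0.07 log units; within the scatter), which shows that lengthening the chain at this position changed nothing beyond the scatter. Within the data shown here, no measured step introduces a halogen, so the effect of chloro here is unknown. The expectation for compound 3 therefore rests on the flat response of the chain, and the step of a 1.1-fold lower number from compound 2 to compound 3 (0.04 log units; within the scatter) is expected to stay near zero. Compound 3 is estimated at 11000 nM, within 4000 nM to 30000 nM.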

Compound 3, half-maximal inhibitory concentration: 12000 nM
Estimate against measurement, compound 3: 1.1-fold (0.04 log units) below; the range from low to high includes it.
By their numbers in this assay, from the lowest: compounds 2, 3 and 1 (each within the scatter of the next).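

In this assay, chloro in place of propyl gives no change at the digits printed from compound 2 to compound 3 (within the scatter), and chloro in place of hydrogen gives a 1.2-fold lower number from compound 1 to compound 3 (0.07 log units; within the scatter). The earlier pair covered only hydrogen and propyl; this result adds a halogen at the same saturated chain carbon, two bonds along the chain from a carbonyl carbon, and all three compounds lie within the scatter of one another. No accompanying data bear on why this position gives so flat a response.

As far as these compounds go, an amine, a carboxylic acid or a chain longer than propyl at this carbon remains open, so the flat response is established only for hydrogen, propyl and chloro. From the compounds shown here alone, whether any change at this position, or elsewhere on the shared core, moves the number beyond the scatter also remains open.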